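The compounds below may be only part of what the source reports. "The series", "measured", "known", "first", "only" and "open" are said of these compounds alone.

Three related compounds have been tested in a functional assay on HepG2 cells (Homo sapiens) for antiproliferative activity, read by CCK-8 assay, with a stated time of 72 h, tested at 2 uM; on this read-out higher numbers stand for a stronger effect at the one concentration tested and lower numbers for a weaker effect. Compound 1 `CC(C)n1cnc2c(Nc3ccccc3)nc(NCOCc3ccc(C(=O)Nc4ccccc4N)cc3)nc21` gives 6.58%. Compound 2 `CC(C)n1cnc2c(NCc3ccc(C(=O)Nc4ccccc4N)cc3)nc(Cl)nc21` gives 63.8%, and compound 3 `Nc1ccccc1NC(=O)c1ccc(CNc2nc(Cl)nc3c2ncn3C2CCCC2)cc1` gives 54.7%. Compound 1 shows the weakest effect of the three; its gaps to compound 2 and to compound 3 both lie beyond the usual scatter of this kind of measurement. The difference between the core of compound 1 and the core of compound 2 is not broken down here, as the two differ in more than one place.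

Compound 2 and compound 3 differ in a single change, (cyclopentyl in place of isopropyl on an aromatic nitrogen). That change gave a number 9.1 percentage points lower from compound 2 to compound 3 (within the scatter). Compound 4 `Nc1ccccc1NC(=O)c1ccc(COCNc2nc(Nc3ccccc3)c3ncn(C4CCCC4)c3n2)cc1` has not yet been measured; it differs from compound 1 by cyclopentyl in place of isopropyl on an aromatic nitrogen, the same change made at the same kind of place. Because the earlier example gave only a number 9.1 percentage points lower from compound 2 to compound 3 (within the scatter), a step of similar small size is expected here as well. The expected step from compound 1 to compound 4 is a number 2.6 percentage points lower from compound 1 to compound 4 (within the scatter). Compound 4 is estimated to give 4% in this assay, most likely between -6% and 18%. The starting value of compound 1 is already low, so there is little room for a further fall. The estimate rests on one measured example only, and compound 1 and compound 2 also differ elsewhere, which leaves open whether the change behaves the same on both cores.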

Compound 4, a percentage reported as inhibition, at one concentration (the size of the read-out at that concentration, not a potency): 37.5%
For compound 4 the middle estimate is 33.5 percentage points below the measured one, outside the stated range (above it).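

In this assay, putting cyclopentyl in place of isopropyl on an aromatic nitrogen of the core of compound 1 gave a number 30.9 percentage points higher from compound 1 to compound 4 (beyond the scatter). This shows that, among the compounds shown, the change does not carry over from one core to the other with a fixed size, so a step measured on one core is a poor guide to the step on the other, and the two steps differ clearly: the same change on two cores in this assay, a number 9.1 percentage points lower (within the scatter) from compound 2 to compound 3 and a number 30.9 percentage points higher (beyond the scatter) from compound 1 to compound 4, 40 percentage points apart, beyond the scatter of two such steps It does not show why the two steps differ or which part of the surrounding structure matters, and two pairs of compounds are too few to give a rule for the whole series.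

The cores of compound 1 and compound 2 differ in more than one place, so the compounds shown leave open which of those differences goes with the different outcome of the change. They also leave open how other groups on the same aromatic nitrogen, such as methyl or cyclohexyl, would behave on each of the two cores, and whether the size of the step would follow the size of the group.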